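The source may report more compounds than this note shows. Statements on the series, on what has been measured and on what is new or still open speak of the compounds shown alone.

Measured in a functional assay on K562 cells (Homo sapiens) for antiproliferative activity, read by MTT assay, with a stated time of 48 h; a higher number here means a weaker inhibitor of growth, a lower number a stronger inhibitor of growth:

- Compound 1 `COc1ccc(Cn2cnc3c(Cl)ncnc32)cc1`: > 50000 nM (a limit)
- Compound 2 `COc1ccc(Cn2cnc3c(Cl)ncnc32)cc1OC`: > 50000 nM (a limit)

The entry for compound 2 in this assay, > 50000 nM, is a limit of the assay and not a number. The entry for compound 1, > 50000 nM, is also a limit. Taken together, the record so far is the limit of > 50000 nM in this assay, at which 2 of the 2 values shown sit.

Compound 3 `COc1cc(Cn2cnc3c(Cl)ncnc32)cc(OC)c1OC` takes compound 2 one change further: methoxy in place of hydrogen on an aromatic carbon. Going by the values given here, the one measured step that bears on this is of the same kind, methoxy in place of hydrogen on an aromatic carbon. It is a step that the two limits leave unreadable from compound 1 to compound 2, so it gives no size to carry over. With compound 2 at > 50000 nM, no direction can be argued for in this assay, and no step beyond the scatter is expected. Most likely, compound 3 will again be reported only as a limit. The expected change is a number no higher from compound 2 to compound 3 (the limit leaves the size open). For compound 3 the estimate is 50000 nM, with an expected range of 20000 nM to 100000 nM.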

Compound 3, concentration for 50% growth inhibition: > 50000 nM
Compound 3 ended at the assay's limit (the forecaster's own chance of this, stated with the estimate: 80%); the middle value sits exactly at the limit.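

Compound 3, like compound 2, is recorded in this assay only as a limit, so no step can be read between these two compounds: the limit of > 50000 nM in this assay, at which 3 of the 3 values shown sit.

The compounds shown leave open how large the effect of each added methoxy really is, and whether any compound of this series gives a measurable growth inhibition.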